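Amino to Butyl: An Expected Gain in Receptor Binding

The source may report more compounds than this note shows. Statements on the series, on what has been measured and on what is new or still open speak of the compounds shown alone.

Compound 2 `CCCc1cc(N)c2cc(NC(=O)/C=C/c3ccc(N)cc3)ccc2n1` is the weakest binder of the three measured: in an assay on isolated protein for displacement of a labelled ligand from melanin-concentrating hormone receptor 1 (Homo sapiens) (a higher number here means a weaker inhibitor, a lower number a stronger inhibitor), compound 2 gives 190 nM. Compound 1 `CCCc1cc(N)c2cc(NC(=O)/C=C/c3ccc(Cl)cc3Cl)ccc2n1` gives 6.6 nM, and compound 3 `CCCc1cc(N)c2cc(NC(=O)/C=C/c3ccc(Cl)c(Cl)c3)ccc2n1` gives 60 nM. Compound 4 `CCCCc1ccc(/C=C/C(=O)Nc2ccc3nc(CCC)cc(N)c3c2)cc1` differs from compound 2 by a single change: butyl in place of amino on an aromatic carbon. Going by the values given here, two measured steps bear on this. Moving from a chlorinated ring to the amino-bearing ring weakened binding, a 29-fold higher number from compound 1 to compound 2 (1.46 log units; beyond the scatter), while the swap back to a differently chlorinated ring strengthened it, a 3.2-fold lower number from compound 2 to compound 3 (0.50 log units; beyond the scatter). Replacing the amino group with a butyl chain is expected to act in the same direction, so a modest to large lowering of the number is expected, a 4.8-fold lower number from compound 2 to compound 4 (0.68 log units; beyond the scatter). Compound 4 is therefore estimated at 40 nM, with a likely range from 10 nM to 160 nM.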

Compound 4, half-maximal inhibitory concentration: 45 nM
Estimate against measurement, compound 4: 1.1-fold (0.05 log units) below, within the range that was stated.
By their numbers in this assay, from the lowest: compound 1; then compounds 4 and 3 (each within the scatter of the next); then compound 2.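

Swapping amino for butyl on this aromatic carbon, para to a large group, gives a 4.2-fold lower number from compound 2 to compound 4 (0.63 log units; beyond the scatter) in this assay. Until now, this position had only been seen carrying amino or chlorine as part of a changing ring pattern; here a purely carbon chain stands in that place. Binding therefore does not depend on the hydrogen-bond donor and acceptor of the amino group, which butyl lacks. On these data alone, whether a shorter ethyl chain, a longer hexyl chain or an ether such as methoxy would serve as well remains open. Nothing available explains the gain seen with butyl.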